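This account rests on a few compounds, and the source may have more. Where it says the series, first, only, none or still open, it means among the compounds named here.

The measured compounds so far:

Compound 1, `O=C(/C=C\Nc1ccc(O)cc1)c1cn(-c2ccccc2)nc1-c1ccccc1`, which in a functional assay on A549 cells (Homo sapiens) for antiproliferative activity, read by MTT assay, with a stated time of 48 h (a higher number here means a weaker inhibitor, a lower number a stronger inhibitor), gives 3210 nM.
Compound 2, `COc1ccc(N/C=C\C(=O)c2cn(-c3ccccc3)nc2-c2ccccc2)cc1`, which in this assay gives 3250 nM.
Compound 3, `COc1ccc(-c2nn(-c3ccccc3)cc2C(=O)/C=C\Nc2ccc(O)cc2)cc1`, which in this assay gives 2770 nM.

Compound 1 and compound 2 differ in one place: methyl in place of hydrogen on an oxygen on an aromatic ring. That change produced a 1.0-fold higher number from compound 1 to compound 2 (0.01 log units; within the scatter), so the two compounds sit together within the ordinary spread of repeated tests. Compound 3 differs from compound 1 in a different place: methoxy in place of hydrogen on an aromatic carbon. This gave a 1.2-fold lower number from compound 1 to compound 3 (0.06 log units; within the scatter), again a step too small to tell apart from noise. All three measured values therefore lie close together, and none can be called stronger or weaker than another.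

Compound 4, `COc1ccc(N/C=C\C(=O)c2cn(-c3ccccc3)nc2-c2ccc(OC)cc2)cc1`, has not yet been measured. It differs from compound 3 by methyl in place of hydrogen on an oxygen on an aromatic ring. Going by the values given here, this is the same change as the one that turns compound 1 into compound 2, made at the same place, but on a core that differs from that of compound 1 by methoxy in place of hydrogen on an aromatic carbon. Since the earlier step was a 1.0-fold higher number from compound 1 to compound 2 (0.01 log units; within the scatter), the same change on the core of compound 3 is expected to be equally small. Among the compounds with values here, for compound 4 the expected step is a 1.0-fold higher number from compound 3 to compound 4 (0.00 log units; within the scatter), which rests only on the single earlier pair. Compound 4 is therefore estimated to give about 2800 nM in this assay, most likely between 1500 nM and 5200 nM.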

Compound 4, half-maximal inhibitory concentration: 6780 nM
Compound 4: middle estimate off by 2.4-fold (0.38 log units), on the low side, outside the stated range (above it).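

On the core of compound 3, putting a methyl on the oxygen, which turns 4-hydroxyphenyl into 4-methoxyphenyl, gives a 2.4-fold higher number from compound 3 to compound 4 (0.39 log units; beyond the scatter) in this assay, and adding a methoxy on the aromatic carbon of the core of compound 2 gives a 2.1-fold higher number from compound 2 to compound 4 (0.32 log units; beyond the scatter). Each change therefore gives a step beyond the scatter on one core and a step within it on the other, but for the hydroxy to methoxy change the two steps cannot be told apart: the same change on two cores in this assay, a 1.0-fold higher number (0.01 log units; within the scatter) from compound 1 to compound 2 and a 2.4-fold higher number (0.39 log units; beyond the scatter) from compound 3 to compound 4, 2.4-fold (0.38 log units) apart, within the scatter of two such steps The same reading holds for the added methoxy on the aromatic carbon, so the data neither prove that either change behaves differently from one core to another nor prove that it carries over unchanged: the same change on two cores in this assay, a 1.2-fold lower number (0.06 log units; within the scatter) from compound 1 to compound 3 and a 2.1-fold higher number (0.32 log units; beyond the scatter) from compound 2 to compound 4, 2.4-fold (0.38 log units) apart, within the scatter of two such steps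

Going by these compounds alone, each change has been seen on only two cores, so how it would behave on a third core remains an open question. The compounds shown also leave open what would happen if the hydroxy or methoxy were replaced by an amine, a fluorine atom or a longer chain such as ethoxy, and whether any of these would move the number further than the methoxy does.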